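Spirooxindole triazole series: antiproliferative readings on L02 cells

A few compounds are considered here, and "the series" means these few. Any claim that something is new, unique, unknown or untested is made for them only; others in the source may bear on it.

Measured compounds in an ADME assay on L02 cells (Homo sapiens) for antiproliferative activity, read by MTT assay, with a stated time of 48 h; a lower number here means a stronger inhibitor, a higher number a weaker inhibitor:
Compound 1 `N#CC1=C(N)Oc2c(c3nc4ccccc4nc3c3ccccc23)C12C(=O)N(Cc1cnnn1-c1ccc(S(N)(=O)=O)cc1)c1ccccc12` gives > 50000 nM, a limit of the assay.
Compound 2 `Cc1ccc(Cl)cc1-n1nncc1CN1C(=O)C2(C(C#N)=C(N)Oc3c2c2nc4ccccc4nc2c2ccccc32)c2ccccc21` gives > 50000 nM, a limit of the assay.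
Compound 3 `N#CC1=C(N)Oc2c(N)cc3nc4ccccc4nc3c2C12C(=O)N(Cc1cnnn1-c1cccc(Br)c1)c1ccccc12` gives > 50000 nM, a limit of the assay.

Compound 3 stands at the limit of > 50000 nM in this assay, at which 3 of the 3 values shown sit, so no number is known for it. Compound 4 `N#CC1=C(N)Oc2c(N)cc3nc4ccccc4nc3c2C12C(=O)N(Cc1cnnn1-c1ccc(Cl)cc1Cl)c1ccccc12` differs from compound 3 by 2,4-dichlorophenyl in place of 3-bromophenyl on an aromatic nitrogen. For the measured compounds named here, the only measured step on the aromatic nitrogen is a step that the two limits leave unreadable from compound 1 to compound 2, which gives no readable size. On that basis no step beyond the scatter is expected for compound 4 in this assay, and compound 4 is expected to remain at the limit. The estimate for compound 4 is 60000 nM, within 30000 nM to 200000 nM. This expected estimate means a step that the limit leaves unreadable from compound 3 to compound 4.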

Compound 4, half-maximal inhibitory concentration: > 50000 nM
Compound 4 gave a limit, no number (the forecaster's own chance of this, stated with the estimate: 85%); the middle value is on the limit's open side.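

In this assay, for the compounds shown here, compound 4 gives > 50000 nM, a limit and not a number; compound 3 also sits at a limit, so no step between compound 3 and compound 4 can be read. The compounds shown leave open whether any group on the aromatic nitrogen brings a reading off the limit: the limit of > 50000 nM in this assay, at which 4 of the 4 values shown sit.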